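Replacing an Amide Hydrogen Donor with a Methylpiperidine

The compounds below may be only part of what the source reports. "The series", "measured", "known", "first", "only" and "open" are said of these compounds alone.

Within the data shown here, compound 1 `O=C(NC1CCCCC1)c1ccc(C#Cc2ccccc2)nc1` gives 240 nM in a functional assay on BHK cells for positive allosteric modulation of metabotropic glutamate receptor 5 (Homo sapiens), read by FLIPR and calcium flux (a higher number here means that more compound is needed for the effect, a lower number that less compound is needed), the lowest of the three numbers measured so far. Compound 3 `CC1CCN(C(=O)c2ccc(C#Cc3ccccc3)cc2)CC1` gives 720 nM, and compound 2 `O=C(NCc1ccsc1)c1ccc(C#Cc2ccccc2)cc1` gives 1200 nM. Compound 4 `CC1CCN(C(=O)c2ccc(C#Cc3ccccc3)nc2)CC1` has not yet been measured; it differs from compound 1 by 4-methylpiperidin-1-yl in place of cyclohexylamino on a carbonyl carbon. Among the measured compounds shown here, the one measured step that bears on this change is a 1.7-fold lower number from compound 2 to compound 3 (0.22 log units; within the scatter), a related exchange of an amide bearing a hydrogen for the same cyclic amide on a carbonyl carbon, and that step stayed within the scatter. A similarly small step is therefore expected here. Compound 4 is estimated at 200 nM, within a range of 70 nM to 600 nM, which means an expected 1.2-fold lower number from compound 1 to compound 4 (0.08 log units; within the scatter) that should not go beyond the scatter.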

Compound 4, half-maximal effective concentration: 130 nM
For compound 4 the middle estimate is 1.5-fold (0.19 log units) above the measured one, and the stated range covers the measured number.
By their numbers in this assay, from the lowest: compounds 4 and 1 (each within the scatter of the next); then compounds 3 and 2 (each within the scatter of the next).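

In this assay, the exchange on the carbonyl carbon gives a 1.8-fold lower number from compound 1 to compound 4 (0.27 log units; within the scatter). The hydrogen-bond donor of cyclohexylamino can therefore be lost on the core of compound 1 with no step beyond the scatter, just as on the different core shared by compound 2 and compound 3. No measurement shown gives a reason for this outcome. Still open, from the compounds shown here alone, is whether a smaller ring such as pyrrolidin-1-yl, or an open-chain diethylamino group, would fare the same on this carbonyl carbon. Also open, going by these compounds, is what the methyl of 4-methylpiperidin-1-yl contributes, which plain piperidin-1-yl would test.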